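Removing the ring hydroxy: compound 2 to compound 4

A few compounds are considered here, and "the series" means these few. Any claim that something is new, unique, unknown or untested is made for them only; others in the source may bear on it.

Three compounds of the series have numbers in an ADME assay on MRC5 cells (Homo sapiens) for inhibition, with a stated time of 72 h; on this read-out higher numbers stand for an effect only at larger amounts of compound and lower numbers for an effect already at smaller amounts. Compound 1 `CO[C@H]1CC[C@H](NC(=O)c2n[nH]cc2NC(=O)c2cnc3ccccn23)CC1` gives 5900 nM. Compound 3 `CO[C@H]1CC[C@H](NC(=O)c2n[nH]cc2NC(=O)c2ccccc2C(F)(F)F)CC1` gives 3300 nM. Compound 2 `COc1cccc(OC)c1C(=O)Nc1c[nH]nc1C(=O)N[C@H]1CC[C@H](O)CC1` gives 34000 nM, the highest of the three numbers; its nearest neighbour is compound 1, whose number is lower by a margin beyond the scatter, and compound 3 lies further away, again beyond the scatter. For the measured compounds named here, no pair among the measured compounds differs in a single place, so no measured step exists for the change considered here.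

Compound 4 `COc1cccc(OC)c1C(=O)Nc1c[nH]nc1C(=O)NC1CCCCC1` has not been measured in this assay. It differs from compound 2 in one place: hydrogen in place of hydroxy on a saturated ring carbon. Hydrogen in place of hydroxy on a saturated ring carbon has no measured counterpart in the series, so the direction of the step cannot be read from any shown pair. A modest step downward from compound 2 is expected, because compound 2 gives 34000 nM and stands well above the other two, leaving more room below than above. The step from compound 2 to compound 4 is estimated as a 2.3-fold lower number from compound 2 to compound 4 (0.36 log units; beyond the scatter). The estimate for compound 4 in this assay is 15000 nM, with a range from 5000 nM to 45000 nM.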

Compound 4, half-maximal effective concentration: 35000 nM
The estimate for compound 4 lay 2.3-fold (0.37 log units) below the measured number, and the stated range covers the measured number.
By their numbers in this assay, from the lowest: compounds 3 and 1 (each within the scatter of the next); then compounds 2 and 4 (each within the scatter of the next).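

The series now has its first measured single-place step: in this assay, hydrogen in place of hydroxy on a saturated ring carbon gives a 1.0-fold higher number from compound 2 to compound 4 (0.01 log units; within the scatter). With the rest of the molecule held constant, 4-hydroxycyclohexyl and cyclohexyl therefore cannot be told apart on this read-out, and the removal of one hydrogen-bond donor and one hydrogen-bond acceptor at this place leaves no effect beyond the scatter. No measurement shown here offers an explanation for this result.

Going by these compounds, whether the number stays equally unchanged with an amine or a carboxylic acid on this saturated ring carbon remains open. The compounds shown also leave open whether hydrogen in place of a ring substituent gives a similar step with the other end of the molecule as in compound 1 or compound 3, both of which carry a methoxy group on the six-membered ring.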